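This account rests on a few compounds, and the source may have more. Where it says the series, first, only, none or still open, it means among the compounds named here.

Measured so far in an ADME assay on A549 cells (Homo sapiens) for cytotoxicity, read by resazurin assay, with a stated time of 48 h; on this read-out lower numbers stand for higher toxicity in this test and higher numbers for lower toxicity in this test:
- compound 1 `CCCCCCCCC(C)Nc1ccc(NC(=O)c2cc(Cl)ccc2O)c(Cl)c1` gives 21900 nM
- compound 2 `O=C(Nc1ccc(NCC2CCCC2)cc1Cl)c1cc(Cl)ccc1O` gives 21500 nM
- compound 3 `CC1(ON(c2ccc(NC(=O)c3cc(Cl)ccc3O)c(Cl)c2)C2(C)CCCC2)CCCC1` gives 18000 nM

Compound 2 at 21500 nM lies within the scatter of compound 1 and of compound 3, so the three measured compounds sit at one level with no order among them. Compound 4 `O=C(Nc1ccc(NCc2ccc(F)cc2)cc1Cl)c1cc(Cl)ccc1O` has no value yet. Its change from compound 2 is 4-fluorophenyl in place of cyclopentyl on a saturated chain carbon bound to a nitrogen on an aromatic ring and in words it is 4-fluorophenyl in place of cyclopentyl on a saturated chain carbon bound to a nitrogen on an aromatic ring. Among the measured compounds shown here, no measured pair isolates this change. For the measured compounds named here, compound 1 at 21900 nM and compound 3 at 18000 nM carry side groups unlike that of compound 2 and stay within the scatter of it, and this is the only guide available. No step beyond the scatter is therefore expected in this assay in either direction. The estimated step of a 1.2-fold lower number from compound 2 to compound 4 (0.08 log units; within the scatter) stays within the scatter. For compound 4 the estimated value is 18000 nM with an expected range of 8000 nM to 36000 nM for now.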

Compound 4, half-maximal cytotoxic concentration: 54400 nM
Estimate against measurement, compound 4: 3.0-fold (0.48 log units) below; the whole stated range lies below it.
By their numbers in this assay, from the lowest: compounds 3, 2 and 1 (each within the scatter of the next); then compound 4.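

In this assay, among the compounds shown here, the swap of 4-fluorophenyl for cyclopentyl on a saturated chain carbon bound to a nitrogen on an aromatic ring gives a 2.5-fold higher number from compound 2 to compound 4 (0.40 log units; beyond the scatter) and is the first step to go beyond the scatter. This position therefore responds to the nature of its group, and the move from a five-membered non-aromatic ring of carbon only to a six-membered aromatic ring bearing fluorine goes towards lower toxicity in this test. Nothing available explains this step.

This single pair cannot separate the contribution of the aromatic ring from that of the fluorine, so unsubstituted phenyl is the obvious comparison. Also open, from the compounds shown here alone, is how 4-chlorophenyl, 4-methoxyphenyl or a pyridine ring would read at this position.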